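This account rests on a few compounds, and the source may have more. Where it says the series, first, only, none or still open, it means among the compounds named here.

Compound 1 `COc1cc(-c2cc(/C=C/C(=O)c3ccc(Cl)c(Cl)c3)[nH]n2)cc(OC)c1OC` was tested in a functional assay on NCI-H226 cells (Homo sapiens) for cytotoxicity, read by sulforhodamine B assay, with a stated time of 48 h, tested at 0.01 uM (on this read-out lower numbers stand for a stronger effect and higher numbers for a weaker effect at the one concentration tested), where compound 1 gives 103%. Compound 2 `COc1ccc(-c2cc(/C=C/C(=O)c3cc(OC)c(OC)c(OC)c3)[nH]n2)cc1OC` gives 93% in this assay, and compound 3 `COc1cc(C(=O)/C=C/c2cc(-c3cc(OC)c(OC)c(OC)c3)n[nH]2)cc(OC)c1OC` gives 99%; the number for compound 1 sits within the scatter of both of these, so the three compounds cannot be told apart on this read-out. Among the compounds with values here, the one measured step, a number 6 percentage points higher from compound 2 to compound 3 (within the scatter), stayed within the scatter as well. Compound 4 `COc1cc(-c2cc(/C=C/C(=O)c3ccc(F)c(F)c3)[nH]n2)cc(OC)c1OC` differs from compound 1 by 3,4-difluorophenyl in place of 3,4-dichlorophenyl on a carbonyl carbon. Within the data shown here, no measured step exchanges one pair of halogens for another, so no shift beyond the scatter is expected in this assay. The expected step is a number 3 percentage points lower from compound 1 to compound 4 (within the scatter). Compound 4 is estimated at 100%, within a range from 85% to 115%.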

Compound 4, a percentage reported as activity, at one concentration (the size of the read-out at that concentration, not a potency): 99%
Compound 4: the middle estimate sits 1 percentage points above what was measured; measured number inside the range.
By their numbers in this assay, from the lowest: compounds 2, 3, 4 and 1 (each within the scatter of the next).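

Within the data shown here, compounds 1 and 4 give the first direct exchange of one halogen pair for another, here on a carbonyl carbon. The step is a number 4 percentage points lower from compound 1 to compound 4 (within the scatter) in this assay, so 3,4-difluorophenyl and 3,4-dichlorophenyl cannot be told apart at the one concentration tested. Among these compounds, this single pair shows only that this exchange left the read-out within the scatter, and it sets no rule for other groups at this position. As far as these compounds go, whether a phenyl carrying an amine or a carboxylic acid in place of the two halogens would stand apart from compound 1 remains open. No available evidence bears on this result.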